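This account rests on a few compounds, and the source may have more. Where it says the series, first, only, none or still open, it means among the compounds named here.

Measured so far in a functional assay on PC-3 cells (Homo sapiens) for antiproliferative activity, read by MTT assay, with a stated time of 48 h; a higher number here means a weaker inhibitor, a lower number a stronger inhibitor
compound 1 `COc1ccc(CN(C(=O)Cn2cc(CSC3=NCCS3)nn2)c2cc(OC)c(OC)c(OC)c2)cc1` gives 16000 nM
compound 2 `COc1ccc(CN(C(=O)Cn2cc(CSc3nc4ccccc4o3)nn2)c2cc(OC)c(OC)c(OC)c2)cc1` gives 5050 nM
compound 3 `COc1ccc(CN(C(=O)Cn2cc(CSc3nncs3)nn2)c2cc(OC)c(OC)c(OC)c2)cc1` has no value yet

Compound 2 holds the lower of the two numbers, and the gap to compound 1 lies beyond the scatter. Going on to compound 3 brings the change (1,3,4-thiadiazol-2-yl in place of 1,3-benzoxazol-2-yl on a sulfur), which in words is 1,3,4-thiadiazol-2-yl in place of 1,3-benzoxazol-2-yl on a sulfur. Among the measured compounds shown here, one measured step bears on this: a 3.2-fold lower number from compound 1 to compound 2 (0.50 log units; beyond the scatter), a modest move that put 1,3-benzoxazol-2-yl on the same sulfur in place of a smaller non-aromatic ring group. Compound 3 loses the six-membered aromatic ring but keeps a five-membered aromatic ring, so it matches neither compound 1 nor compound 2 at this place. A single step cannot separate ring size from aromatic character. In this assay a move to a higher number is therefore expected, smaller than the measured step. The expected size is a 1.8-fold higher number from compound 2 to compound 3 (0.25 log units; within the scatter), which may not clear the scatter. For compound 3 the estimated value is 9000 nM, with an expected range from 3500 nM to 23000 nM.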

Compound 3, half-maximal inhibitory concentration: 16500 nM
Estimate against measurement, compound 3: 1.8-fold (0.26 log units) below; the range from low to high includes it.
By their numbers in this assay, from the lowest: compound 2; then compounds 1 and 3 (each within the scatter of the next).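

In this assay, 1,3,4-thiadiazol-2-yl in place of 1,3-benzoxazol-2-yl on the sulfur gives a 3.3-fold higher number from compound 2 to compound 3 (0.51 log units; beyond the scatter) and so shows that the earlier advantage of compound 2 does not carry over to this smaller aromatic group. The comparison with the non-aromatic ring gives a 1.0-fold higher number from compound 1 to compound 3 (0.01 log units; within the scatter) and lies within the scatter, so among these three compounds an aromatic five-membered ring alone brings no measurable difference at this sulfur, and only compound 2, with its additional six-membered aromatic ring of carbon only, stands apart. No supporting data are available to explain this pattern.

The compounds shown leave open whether the six-membered aromatic ring itself matters or simply the larger group of 9 heavy atoms, a question that a phenyl or cyclohexyl group on the same sulfur would help to settle. They also leave open what part the ring oxygen of 1,3-benzoxazol-2-yl plays, which 1,3-benzothiazol-2-yl at this place would test.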